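This account rests on a few compounds, and the source may have more. Where it says the series, first, only, none or still open, it means among the compounds named here.

Of the compounds shown here, three have been measured in an ADME assay on BJ cells (Homo sapiens) for cytotoxicity, read by luminescence, with a stated time of 72 h; a lower number here means that less compound is needed, a higher number that more compound is needed for the effect.

Compound 1 `CCOC(=O)c1c(-c2cccc(-c3ccccc3)c2)[nH]c2cc(OC)ccc2c1=O`: > 21500 nM, a limit of the assay.
Compound 2 `CCOC(=O)c1c(-c2cccc(OC(C)C)c2)[nH]c2cc(OC)ccc2c1=O`: > 21500 nM, a limit of the assay.
Compound 3 `CCOC(=O)c1c(-c2cccc(F)c2)[nH]c2cc(OC)ccc2c1=O`: > 21500 nM, a limit of the assay.

Compound 1 thus stands only at a limit in this assay, and the two other values shown are limits as well, as the limit of > 21500 nM in this assay, at which 3 of the 3 values shown sit, records. Because the limit of > 21500 nM in this assay, at which 3 of the 3 values shown sit, holds all three values, the steps among them cannot be read: a step that the two limits leave unreadable from compound 1 to compound 2, a step that the two limits leave unreadable from compound 1 to compound 3 and a step that the two limits leave unreadable from compound 2 to compound 3 all remain of unknown size, and their direction is not told.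

The next compound to be measured is compound 4 `CCOC(=O)c1c(-c2cccc(S(C)(=O)=O)c2)[nH]c2cc(OC)ccc2c1=O`. It differs from compound 1 in one place: methylsulfonyl in place of phenyl on an aromatic carbon. The measured steps that replace the phenyl with isopropoxy or fluoro are the ones that bear on this change, and each of them was left unreadable by the limit. No step beyond the scatter is therefore expected in this assay for the change from compound 1 to compound 4, and the outcome is expected most likely to be another limit. The estimate for compound 4 is 30000 nM, within 10000 nM to 100000 nM, which is expected to mean a step that the limit leaves unreadable from compound 1 to compound 4.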

Compound 4, half-maximal effective concentration: > 21500 nM
Compound 4: no number, only a limit; the forecaster's own chance of this, stated with the estimate: 80%; the middle value does not contradict the limit.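

Compound 4 also gives only a limit in this assay and so adds no readable step: the steps linking it to compound 1, compound 2 and compound 3 cannot be read, with the values recorded as follows: the limit of > 21500 nM in this assay, at which 4 of the 4 values shown sit.

The compounds shown leave open how far the four lie from one another in this assay and whether any change on the shared core would give a value inside the limit.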